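The source may report more compounds than this note shows. Statements on the series, on what has been measured and on what is new or still open speak of the compounds shown alone.

Compound 3 `CC(C)(N)C(=O)N[C@H](COCc1ccccc1)c1nnnn1CCOC(=O)N1CC[C@@H](O)C1` holds the lowest number of the three measured compounds: in a functional assay on H4 cells with growth hormone secretagogue receptor type 1 (Homo sapiens) as the target, read by FLIPR (on this read-out higher numbers stand for an effect only at larger amounts of compound and lower numbers for an effect already at smaller amounts), compound 3 gives 1 nM. Its nearest neighbour is compound 1 `CC(C)(N)C(=O)N[C@H](COCc1ccccc1)c1nnnn1CCOC(=O)NCCO`, which gives 3 nM, while compound 2 `CC(C)(N)C(=O)N[C@H](COCc1ccccc1)c1nnnn1CCOC(=O)NCCCO` gives 5.5 nM. Compound 4 `CC(=O)NCCCCNC(=O)OCCn1nnnc1[C@@H](COCc1ccccc1)NC(=O)C(C)(C)N` has not yet been measured; it differs from compound 3 by (4-acetamidobutyl)amino in place of 3-hydroxypyrrolidin-1-yl on a carbonyl carbon. Within the data shown here, two measured steps bear on this change: a 3.0-fold lower number from compound 1 to compound 3 (0.48 log units; beyond the scatter) and a 5.5-fold lower number from compound 2 to compound 3 (0.74 log units; beyond the scatter), both moving from an open-chain (2-hydroxyethyl)amino or (3-hydroxypropyl)amino group to the ring. Compound 4 returns to an open chain on that carbonyl carbon, so a modest step upwards in this assay is expected, namely a 5.0-fold higher number from compound 3 to compound 4 (0.70 log units; beyond the scatter). Compound 4 is therefore estimated at 5 nM, with a range from 2 nM to 15 nM.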

Compound 4, half-maximal effective concentration: 82.5 nM
The estimate for compound 4 lay 17-fold (1.22 log units) below the measured number; measured number outside the range, above it.
By their numbers in this assay, from the lowest: compound 3; then compounds 1 and 2 (each within the scatter of the next); then compound 4.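

In this assay, among these compounds, this carbonyl position proves far more sensitive to the group on it than the earlier compounds showed, with an 83-fold higher number from compound 3 to compound 4 (1.92 log units; beyond the scatter). The open-chain comparisons are also large, with a 28-fold higher number from compound 1 to compound 4 (1.44 log units; beyond the scatter) and a 15-fold higher number from compound 2 to compound 4 (1.18 log units; beyond the scatter), whereas the earlier step between the two hydroxy chains lay within the scatter. So being an open chain rather than a ring does not alone set the number, as compounds 1, 2 and 4 all carry open chains.

On these data alone, whether chain length or the acetamido end drives the rise stays open, and a (4-hydroxybutyl)amino group would separate the two. Nothing available gives a reason for the rise.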